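A Methyl Added to the Same Side Chain on Two Cores

The compounds below may be only part of what the source reports. "The series", "measured", "known", "first", "only" and "open" are said of these compounds alone.

Compound 1 `COc1cc2ncnc(Nc3ccc(C)cc3)c2cc1OCCCCC(=O)Nc1ccc(S(N)(=O)=O)cc1` and compound 2 `CCc1ccc(Nc2ncnc3cc(OC)c(OCCCCC(=O)Nc4ccc(S(N)(=O)=O)cc4)cc23)cc1` share one core, while compound 3 `Cc1ccc(Nc2ncnc3ccc(NC(=S)Nc4ccc(S(N)(=O)=O)cc4)cc23)cc1` and compound 4 `CCc1ccc(Nc2ncnc3ccc(NC(=S)Nc4ccc(S(N)(=O)=O)cc4)cc23)cc1` share another; the difference between the two cores is not broken down here. In a functional assay on A-431 cells (Homo sapiens) for antiproliferative activity, read by MTT assay, with a stated time of 72 h (on this read-out higher numbers stand for weaker inhibition and lower numbers for stronger inhibition), compound 1 gives 35500 nM, and compound 2 gives 7220 nM. Among the measured compounds shown here, the only change between them is methyl in place of hydrogen on a saturated chain carbon bound to an aromatic carbon, and it brought a 4.9-fold lower number from compound 1 to compound 2 (0.69 log units; beyond the scatter). In this assay compound 3 gives 40000 nM, which sits within the scatter of compound 1. Compound 4 carries the same change on the other core: methyl in place of hydrogen on a saturated chain carbon bound to an aromatic carbon. The place of the change reads the same on both cores, so it is the same change, not merely the same kind. For the measured compounds named here, the expectation for compound 4 rests on the one measured example, in which the change gave a 4.9-fold lower number from compound 1 to compound 2 (0.69 log units; beyond the scatter). Going by the values given here, since only a single example exists and the core is different, a somewhat smaller step is expected, namely a 3.3-fold lower number from compound 3 to compound 4 (0.52 log units; beyond the scatter). Compound 4 is therefore estimated at 12000 nM, with a range from 4000 nM to 40000 nM.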

Compound 4, half-maximal inhibitory concentration: 38400 nM
Estimate against measurement, compound 4: 3.2-fold (0.51 log units) below; the measured number falls inside the stated range.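

In this assay, the change from 4-methylphenyl to 4-ethylphenyl brought a 1.0-fold lower number from compound 3 to compound 4 (0.02 log units; within the scatter) and so made no clear difference on this core. On the other core, the same change did move the number, so the two cores do not respond alike: the same change on two cores in this assay, a 4.9-fold lower number (0.69 log units; beyond the scatter) from compound 1 to compound 2 and a 1.0-fold lower number (0.02 log units; within the scatter) from compound 3 to compound 4, 4.7-fold (0.67 log units) apart, beyond the scatter of two such steps. This shows that the size of the step on one core could not be carried over to the other in this series, but with one pair per core it does not show why they differ, and the difference between the cores is not broken down here, so no part of it can be held responsible.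

On these data alone, it remains open whether a longer chain, such as propyl or butyl, in place of the ethyl would again separate the two cores. As far as these compounds go, it also remains open whether a carboxylic acid or an amine at this place would give similar numbers on both cores.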